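From diethylamino to methoxy on a shared core

This account rests on a few compounds, and the source may have more. Where it says the series, first, only, none or still open, it means among the compounds named here.

In a functional assay on HeLa cells (Homo sapiens) for antiproliferative activity, read by WST assay, with a stated time of 24 h (on this read-out higher numbers stand for weaker inhibition and lower numbers for stronger inhibition), compound 3 `C=C[C@]1(C)CC[C@@H](C(=C)CN(CC)CC)C[C@H]1C(=C)C` gives 14400 nM, within the scatter of compound 1 `C=C[C@]1(C)CC[C@@H](C(=C)Cn2ccnc2)C[C@H]1C(=C)C`, which gives 15700 nM. Compound 2 `C=C[C@]1(C)CC[C@@H](C(=C)COCCCC)C[C@H]1C(=C)C` gives 266000 nM. Compound 4 `C=C[C@]1(C)CC[C@@H](C(=C)COC)C[C@H]1C(=C)C` has methoxy in place of diethylamino on a saturated chain carbon bound to a double-bonded chain carbon. Among the compounds with values here, two measured steps bear on this change, both involving butoxy: a 17-fold higher number from compound 1 to compound 2 (1.23 log units; beyond the scatter) and an 18-fold lower number from compound 2 to compound 3 (1.27 log units; beyond the scatter). The data do not show how methoxy compares with butoxy, so the range stays wide. A large step is expected toward a higher number, with an estimated 10-fold higher number from compound 3 to compound 4 (1.02 log units; beyond the scatter). Compound 4 is expected to give about 150000 nM, within an estimated range of 45000 nM to 400000 nM.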

Compound 4, half-maximal inhibitory concentration: 212000 nM
Estimate against measurement, compound 4: 1.4-fold (0.15 log units) below; the range from low to high includes it.
By their numbers in this assay, from the lowest: compounds 3 and 1 (each within the scatter of the next); then compounds 4 and 2 (each within the scatter of the next).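

In this assay, methoxy does not separate from butoxy on this saturated chain carbon bound to a double-bonded chain carbon (a 1.3-fold lower number from compound 2 to compound 4 (0.10 log units; within the scatter)), so the shorter ether does not bring back what the butoxy compound lacked. Both groups attached through nitrogen stand apart from methoxy, diethylamino (a 15-fold higher number from compound 3 to compound 4 (1.17 log units; beyond the scatter)) as well as 1H-imidazol-1-yl (a 14-fold higher number from compound 1 to compound 4 (1.13 log units; beyond the scatter)). Among these four compounds, the two nitrogen-linked groups give the lower numbers and the two ethers the higher, and no compound goes against this. Nothing shown here accounts for the split. Going by these compounds, whether a primary amine or a carboxylic acid at this place would stand with the nitrogen-linked groups or with the ethers remains open.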